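Adding to One Side Chain of Compound 1

The source may hold more compounds than are shown below. What is called first, only, known or untested is meant among the compounds shown, and "the series" means these compounds.

Among the measured compounds shown here, in a functional assay on SGC-7901 cells (Homo sapiens) for inhibition (on this read-out lower numbers stand for stronger inhibition and higher numbers for weaker inhibition), compound 1 `CC(C)=CCC/C(C)=C/C[C@]12C(=O)CC(=O)[C@](CC=C(C)C)(C[C@@H](CC=C(C)C)C1(C)C)C2=O` gives 8.5 ug/mL and holds the higher of the two numbers measured so far. Compound 2 `CC(C)=CCC/C(C)=C/C[C@@H]1C[C@]2(C/C=C(\C)CCC=C(C)C)C(=O)[C@@](CC=C(C)C)(C(=O)C(C(=O)c3ccc(O)c(O)c3)=C2O)C1(C)C` gives 4.05 ug/mL and lies lower, beyond the scatter. Compound 3 `CC(C)=CCC/C(C)=C/C[C@]12C[C@@H](CC=C(C)C)C(C)(C)[C@](C/C=C(\C)CCC=C(C)C)(C(=O)CC1=O)C2=O` keeps the core of compound 1 and differs from it by one change: 3-methylbut-2-en-1-yl in place of hydrogen on a saturated chain carbon bound to a double-bonded chain carbon with 3-methylbut-2-en-1-yl in place of hydrogen on a saturated chain carbon bound to a double-bonded chain carbon. For the measured compounds named here, no measured pair differs in one place, so the estimated 1.1-fold lower number from compound 1 to compound 3 (0.03 log units; within the scatter) in this assay is expected to stay within the scatter. Compound 3 is estimated at 8 ug/mL (expected range 3.5 ug/mL to 18 ug/mL).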

Compound 3, half-maximal inhibitory concentration: > 20 ug/mL
Compound 3 ended at the assay's limit; the forecaster's own chance of this, stated with the estimate: 5%; at least 2.5-fold (0.39 log units) between middle value and limit.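

In this assay compound 3 gives > 20 ug/mL, which is a limit of the assay. Among the compounds shown here, the exchange of 3-methylbut-2-en-1-yl for 3,7-dimethylocta-2,6-dien-1-yl gives an at least 2.3-fold higher number from compound 1 to compound 3 (0.37 log units; beyond the scatter), the first readable step at this position, and it shows that this longer chain moves the read-out toward weaker inhibition. The step gives only a minimum size: the limit of > 20 ug/mL in this assay, at which 1 of the 3 values shown sits.

Going by these compounds, how far compound 3 lies past that limit remains open. Also open, on these data alone, is whether a shorter chain, an amine or a carboxylic acid here would keep the number of compound 1.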